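This account rests on a few compounds, and the source may have more. Where it says the series, first, only, none or still open, it means among the compounds named here.

In a functional assay on MIA PaCa-2 cells (Homo sapiens) for inhibition (on this read-out lower numbers stand for stronger inhibition and higher numbers for weaker inhibition), compound 1 (`O=C1O/C(=C\Cn2ccc(=O)[nH]c2=O)C(OCc2ccccc2)=C1OCc1ccccc1`) gives 30000 nM and compound 2 (`O=C1O/C(=C\Cn2cc(Cl)c(=O)[nH]c2=O)C(OCc2ccccc2)=C1OCc1ccccc1`) gives 40000 nM, so compound 2 stands level with compound 1 within the scatter. Compound 3 (`O=C1O/C(=C\Cn2cc(F)c(=O)[nH]c2=O)C(OCc2ccccc2)=C1OCc1ccccc1`) differs from compound 2 by one exchange: fluoro in place of chloro on an aromatic carbon. For the measured compounds named here, the only measured step at this place is chloro in place of hydrogen, a 1.3-fold higher number from compound 1 to compound 2 (0.12 log units; within the scatter), and it stays within the scatter. No change beyond the scatter is therefore expected in this assay. The expected step is a 1.3-fold lower number from compound 2 to compound 3 (0.12 log units; within the scatter). For compound 3 the estimated value is 30000 nM, with an expected range of 12000 nM to 70000 nM.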

Compound 3, half-maximal inhibitory concentration: 40000 nM
Compound 3: middle estimate off by 1.3-fold (0.12 log units), on the low side, within the range that was stated.
By their numbers in this assay, from the lowest: compounds 1, 2 and 3 (each within the scatter of the next).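

In this assay fluoro in place of chloro on this aromatic carbon gives no change at the digits printed from compound 2 to compound 3 (within the scatter) and leaves the two halogens level, while fluoro in place of hydrogen gives a 1.3-fold higher number from compound 1 to compound 3 (0.12 log units; within the scatter) as the second halogen step at the same place. Hydrogen, chloro and fluoro at this position therefore all stand level within the scatter, and this read-out does not separate them. No available evidence bears on this level result.

Going by these compounds, whether a larger group here, such as an amine, a nitrile or a carboxylic acid, would move the number remains open.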